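Swapping Chlorophenyl for Pyridinyl: Expected Liver Clearance

The source may report more compounds than this note shows. Statements on the series, on what has been measured and on what is new or still open speak of the compounds shown alone.

Measured so far:
Compound 1, `CN1C[C@H](C(=O)Nc2cccc(Cl)c2)[C@@H](c2ccc(/C=C/C(=O)Nc3ccccc3N)cc2)C1`: 7 mL/min/kg
Compound 2, `Cc1cccc(NC(=O)[C@H]2CN(C)C[C@@H]2c2ccc(/C=C/C(=O)Nc3ccccc3N)cc2)c1`: 14 mL/min/kg

In an in vitro ADME assay on microsomes from liver (Homo sapiens) for pharmacokinetics, read by LC-MS, with a stated time of 10 min, tested at 1 uM (on this read-out lower numbers stand for slow clearance and higher numbers for fast clearance), compound 1 gives 7 mL/min/kg, the lower of the two numbers, although the step of a 2.0-fold higher number from compound 1 to compound 2 (0.30 log units; within the scatter) lies within the scatter. Compound 3, `CN1C[C@H](C(=O)Nc2ccccn2)[C@@H](c2ccc(/C=C/C(=O)Nc3ccccc3N)cc2)C1`, differs from compound 1 in one place: pyridin-2-yl in place of 3-chlorophenyl on an amide-type nitrogen. Within the data shown here, no measured step involves this kind of change; the only step available, a methyl in place of chloro, bears on it not at all. The expectation is therefore no step beyond the scatter, a 1.1-fold higher number from compound 1 to compound 3 (0.06 log units; within the scatter). For compound 3 the estimate in this assay is 8 mL/min/kg, ranging from 4 mL/min/kg to 16 mL/min/kg.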

Compound 3, clearance: 8 mL/min/kg
Beside the measured number, compound 3's estimate shows no gap at the digits printed, and the stated range covers the measured number.
By their numbers in this assay, from the lowest: compounds 1, 3 and 2 (each within the scatter of the next).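

In this assay, the amide-type nitrogen carries a ring with a hetero atom much as it carries a ring of carbon only: a 1.1-fold higher number from compound 1 to compound 3 (0.06 log units; within the scatter), and a 1.8-fold lower number from compound 2 to compound 3 (0.24 log units; within the scatter). Among these compounds, the earlier pair compared only two carbon-only rings, whereas 3-chlorophenyl, 3-methylphenyl and pyridin-2-yl now all sit here with no step beyond the scatter. Nothing measured here explains this result. Still open, from the compounds shown here alone, is whether an amine or a carboxylic acid on this nitrogen's ring would also stay within the scatter.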